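A few compounds are considered here, and "the series" means these few. Any claim that something is new, unique, unknown or untested is made for them only; others in the source may bear on it.

Measured so far in a functional assay on KB cells (Homo sapiens) for inhibition, read by colorimetric assay, with a stated time of 72 h; a higher number here means that more compound is needed for the effect, a lower number that less compound is needed:

Compound 1, `Cc1cc2c(cc1C)[n+]([O-])nn2C`, gives only a limit of the assay, > 100 ug/mL.
Compound 2, `CC1=CC(=O)c2nn(C)nc2C1=O`, gives 2.5 ug/mL.
Compound 3, `COC(=O)Cn1n[n+]([O-])c2cc(C)c(C)cc21`, gives only a limit of the assay, > 100 ug/mL.

Compound 1 and compound 3 share one core, and compound 3 differs from compound 1 in a single place: methoxycarbonyl in place of hydrogen on a saturated chain carbon bound to an aromatic nitrogen. The step that the two limits leave unreadable from compound 1 to compound 3 has no readable size, due to the limit of > 100 ug/mL in this assay, at which 2 of the 3 values shown sit, so this pair shows nothing about whether the added group helps or hurts. Compound 2 is built on a different core; the difference between the two cores is not broken down here, and compound 2 is the only one of the three to give a number rather than a limit in this assay.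

Among the compounds with values here, compound 4, `COC(=O)Cn1nc2c(n1)C(=O)C(C)=CC2=O`, is the not yet measured partner of compound 2 and carries the same change as the one from compound 1 to compound 3: methoxycarbonyl in place of hydrogen on a saturated chain carbon bound to an aromatic nitrogen. The place lines of the two changes agree word for word, so it is the same change on a second core. Its expected size rests on little, because compound 2 gives 2.5 ug/mL while the only measured version of this change is unreadable. The step of a 2.0-fold higher number from compound 2 to compound 4 (0.30 log units; within the scatter) is therefore expected to be modest, with wide uncertainty in either direction. Compound 4 is expected to give about 5 ug/mL, somewhere between 1 ug/mL and 30 ug/mL.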

Compound 4, concentration for half-maximal effect: 1.5 ug/mL
Estimate against measurement, compound 4: 3.3-fold (0.52 log units) above; low and high end bracket the measured number.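

On the core of compound 2, the change is a small one in this assay: the step is a 1.7-fold lower number from compound 2 to compound 4 (0.22 log units; within the scatter), so adding methoxycarbonyl on a saturated chain carbon bound to an aromatic nitrogen leaves two compounds that cannot be told apart in this test. This shows that the core of compound 2 tolerates this group here, in the sense that compound 4 still gives a readable number, but it does not show that the change acts alike on both cores, since the step on the core of compound 1 cannot be read and there is nothing to set beside the new step, due to the assay limit: the limit of > 100 ug/mL in this assay, at which 2 of the 4 values shown sit. One readable step on one core is therefore a single observation and not a rule for the series.

The compounds shown leave open whether a carboxylic acid or an amide in place of the methyl ester, or a longer chain carrying the ester, would give a number that stands clearly apart from that of compound 2. They also leave open how any such group would read on the core of compound 1, where both compounds shown give only a limit.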